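Adding Bromo to the Weaker of Two Compounds

This account rests on a few compounds, and the source may have more. Where it says the series, first, only, none or still open, it means among the compounds named here.

Among the measured compounds shown here, only two compounds have been measured so far in a functional assay on the whole organism with Scenedesmus acutus as the target, with a stated time of 20 h; a lower number here means a stronger inhibitor, a higher number a weaker inhibitor. Compound 1 `S=c1n(-c2ccc(Cl)cc2)c(=S)n2n1CCCC2`, which carries a chloro group on its outer aromatic ring, gives 50.1 nM. With hydrogen in that place on the same core, compound 2 `S=c1n(-c2ccccc2)c(=S)n2n1CCCC2` gives 2040 nM, the higher of the two numbers, which makes it the weaker inhibitor.

Compound 3 `S=c1n(-c2ccc(Br)cc2)c(=S)n2n1CCCC2` starts from compound 2 and makes a single change: bromo in place of hydrogen on an aromatic carbon. For the measured compounds named here, only one measured step bears on this change. Replacing chloro with hydrogen gives a 41-fold higher number from compound 1 to compound 2 (1.61 log units; beyond the scatter), a large step well beyond the scatter. Compound 3 puts a bromo group where compound 1 has its chloro, so that step, read backwards, is the best available guide. Going by the values given here, it is still a thin one, since it is a single pair and no bromo compound has yet been measured in this assay. The expected result is a large move to a lower number, close in size to the chloro step: a 37-fold lower number from compound 2 to compound 3 (1.57 log units; beyond the scatter). Compound 3 is therefore estimated at 55 nM, with an expected range from 20 nM to 170 nM.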

Compound 3, half-maximal inhibitory concentration: 46.8 nM
Compound 3: middle estimate off by 1.2-fold (0.07 log units), on the high side; the measured number falls inside the stated range.
By their numbers in this assay, from the lowest: compounds 3 and 1 (each within the scatter of the next); then compound 2.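

In this assay, among the compounds shown here, the large gain at this place on the outer aromatic ring is no longer tied to chloro alone: bromo in place of hydrogen gives a 44-fold lower number from compound 2 to compound 3 (1.64 log units; beyond the scatter), a step of the same large size as the one linking compound 1 and compound 2. Exchanging one of these two groups for the other gives a 1.1-fold lower number from compound 1 to compound 3 (0.03 log units; within the scatter), so compound 1 and compound 3 cannot be told apart in this assay, and the choice between chloro and bromo makes no measurable difference here. Among these three compounds, the hydrogen of compound 2 is what stands apart, with steps beyond the scatter to both others, which makes compound 2 the weakest of the set.

As far as these compounds go, whether the gain extends to other groups at the same place, such as fluoro, methoxy or an amine, remains open, as does whether bromo would keep it on a different carbon of the ring. No measurement shown here says what lies behind these steps.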